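A Naphthyl Group in Place of a Chlorophenyl

A few compounds are considered here, and "the series" means these few. Any claim that something is new, unique, unknown or untested is made for them only; others in the source may bear on it.

Measured so far in a functional assay on MCF7 cells (Homo sapiens) for antiproliferative activity, read by MTT assay, with a stated time of 72 h; a higher number here means a weaker inhibitor, a lower number a stronger inhibitor:
Compound 1, `Cc1cccc(CSc2cc(Cl)c(C)cc2S(=O)(=O)/N=C(\N)N/N=C/C#Cc2ccccc2)c1`, gives 16000 nM.
Compound 2, `Cc1cc(S(=O)(=O)/N=C(\N)N/N=C/C#Cc2ccccc2)c(SCc2ccccc2Cl)cc1Cl`, gives 15000 nM.

Compound 2 has the lower of the two numbers, but its distance to compound 1 is within the scatter, so the two cannot be told apart. Within the data shown here, the only measured step, a 1.1-fold lower number from compound 1 to compound 2 (0.03 log units; within the scatter), exchanged one aryl group for another on a saturated chain carbon bound to a sulfur and left the read-out essentially unchanged.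

Compound 3, `Cc1cc(S(=O)(=O)/N=C(\N)N/N=C/C#Cc2ccccc2)c(SCc2cccc3ccccc23)cc1Cl`, continues on that same carbon: naphthalen-1-yl in place of 2-chlorophenyl on a saturated chain carbon bound to a sulfur. Among the measured compounds shown here, the single step that bears on this change is the one from compound 1 to compound 2, and it was flat. The entering group is larger than anything tried so far, so the evidence is thin, but nothing measured points in either direction. The expectation is therefore a step of no more than the scatter, a 1.1-fold lower number from compound 2 to compound 3 (0.03 log units; within the scatter), in this assay. Compound 3 is estimated at 14000 nM, with a range from 5000 nM to 40000 nM.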

Compound 3, half-maximal inhibitory concentration: 22000 nM
For compound 3 the middle estimate is 1.6-fold (0.20 log units) below the measured one; measured number inside the range.
By their numbers in this assay, from the lowest: compounds 2, 1 and 3 (each within the scatter of the next).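

Measured in this assay the naphthalen-1-yl group gives a 1.5-fold higher number from compound 2 to compound 3 (0.17 log units; within the scatter) when it replaces 2-chlorophenyl and a 1.4-fold higher number from compound 1 to compound 3 (0.14 log units; within the scatter) when it replaces 3-methylphenyl on a saturated chain carbon bound to a sulfur. Among these compounds, the earlier step compared only two groups with one six-membered aromatic ring each, whereas this change brings in 2 such rings and 10 heavy atoms in place of the 7 of 2-chlorophenyl, and even so the read-out does not move beyond the scatter, so the three aryl groups cannot be told apart here. No measurement among the data shown offers an explanation for these small steps.

Going by these compounds, all three compounds carry an aryl group on this carbon, so it remains open whether a group of another kind, such as a carboxylic acid, a piperidine ring or a simple cyclohexyl ring, would shift the number beyond the scatter. A longer chain between the sulfur and the aryl ring, such as 2-phenylethyl in place of benzyl, is also left open, as is any change elsewhere on the shared core.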